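A few compounds are considered here, and "the series" means these few. Any claim that something is new, unique, unknown or untested is made for them only; others in the source may bear on it.

Going by the values given here, the three measured members share the core seen in compound 3 `CC(C)=CCC1Cc2c(OCCCOc3ccc(Cl)cc3)cc(=O)n(CCCO)c2CC1(C)C` and differ only in the chain on the ring oxygen. In a functional assay on PANC-1 cells (Homo sapiens) for inhibition, read by MTT assay, with a stated time of 24 h, tested at 10 uM (a lower number here means less inhibition, a higher number more inhibition at the concentration tested (going by the name of the read-out)), compound 1 `COc1ccc(C(=O)NCCCOc2cc(=O)n(CCCO)c3c2CC(CC=C(C)C)C(C)(C)C3)cc1` gives 2.5%, compound 2 `COc1ccc(OCCCOc2cc(=O)n(CCCO)c3c2CC(CC=C(C)C)C(C)(C)C3)cc1` gives 4.1%, and compound 3 gives 0%, the lowest of the three numbers shown, though every step among them stays within the scatter: a number 1.6 percentage points higher from compound 1 to compound 2 (within the scatter), a number 2.5 percentage points lower from compound 1 to compound 3 (within the scatter), a number 4.1 percentage points lower from compound 2 to compound 3 (within the scatter). Compound 4 `CC(C)=CCC1Cc2c(OC(=O)Nc3ccc(F)c(Cl)c3)cc(=O)n(CCCO)c2CC1(C)C` is not yet measured; relative to compound 3 the change is (3-chloro-4-fluorophenyl)carbamoyl in place of 3-(4-chlorophenoxy)propyl on an oxygen on an aromatic ring. Among the compounds with values here, none of the measured steps alters the oxygen on the aromatic ring itself, so they bear only loosely on this change, and all were within the scatter. In this assay compound 4 is therefore expected near the others, estimated at 3% (range 0% to 15%). The expected step is a number 3 percentage points higher from compound 3 to compound 4 (within the scatter), not beyond the scatter.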

Compound 4, a percentage reported as inhibition, at one concentration (the size of the read-out at that concentration, not a potency): 0%
The estimate for compound 4 lay 3 percentage points above the measured number; measured number inside the range.
By their numbers in this assay, from the lowest: compounds 3, 4, 1 and 2 (each within the scatter of the next).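

Moving from an ether chain to (3-chloro-4-fluorophenyl)carbamoyl on the oxygen on an aromatic ring gives, in this assay, no change at the digits printed from compound 3 to compound 4 (within the scatter). This step alters the group on that oxygen directly, and the entering group adds a hydrogen-bond donor and a double bond outside aromatic rings at a matching heavy-atom count, with no separation in this read-out. No supporting data bear on why the number stays put. Still open, from the compounds shown here alone, is whether an amine or a carboxylic acid on a chain at this oxygen would give a number beyond the scatter.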